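Swapping the Ester Promoiety in a Carbapenem Prodrug

The source may report more compounds than this note shows. Statements on the series, on what has been measured and on what is new or still open speak of the compounds shown alone.

Compounds measured so far:
- Compound 1, `Cc1oc(=O)oc1COC(=O)c1cccc(NC(=O)[C@@H]2C[C@H](SC3=C(C(=O)O)N4C(=O)[C@H]([C@@H](C)O)[C@H]4[C@H]3C)CN2)c1`: in an ADME assay for metabolic stability, read by LC-MS, with a stated time of 3 h, at pH 6.5, tested at 50 uM (a lower number here means that less of the compound is left, a higher number that more of the compound is left), compound 1 gives > 95%, a limit of the assay rather than a number.
- Compound 2, `Cc1oc(=O)oc1COC(=O)C1=C(S[C@@H]2CN[C@H](C(=O)Nc3cccc(C(=O)OCc4oc(=O)oc4C)c3)C2)[C@H](C)[C@@H]2[C@@H]([C@@H](C)O)C(=O)N12`: in this assay compound 2 gives > 95%, again a limit.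

Going by the values given here, compound 1 therefore stands at the top edge of what this assay can report, and so does its only measured neighbour; the step that the two limits leave unreadable from compound 1 to compound 2 cannot be sized because both ends are limits, which is all that the limit of > 95% in this assay, at which 2 of the 2 values shown sit, shows. The unmeasured compound 3, `CC(C)C(=O)OCOC(=O)c1cccc(NC(=O)[C@@H]2C[C@H](SC3=C(C(=O)O)N4C(=O)[C@H]([C@@H](C)O)[C@H]4[C@H]3C)CN2)c1`, differs from compound 1 by a group of 6 heavy atoms (4 carbon, 2 oxygen; no ring) in place of a group of 7 heavy atoms (4 carbon, 3 oxygen; one five-membered aromatic ring with 2 hetero atoms), on a saturated chain carbon bound to an oxygen next to a carbonyl group. Among the compounds with values here, no measured step touches this kind of exchange, so the expectation leans only on where compound 1 sits. Compound 3 is expected to give 92%, between 78% and 99%, meaning an estimated step of a number at least 3 percentage points lower from compound 1 to compound 3 (that floor lies within the scatter) that would stay within the scatter.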

Compound 3, percent of the compound remaining: > 95%
Compound 3 ended at the assay's limit; the forecaster's own chance of this, stated with the estimate: 55%; at least 3 percentage points between middle value and limit.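

Compound 3 gives > 95% in this assay, a limit of the assay and not a number. Going by these compounds alone, no step can therefore be read from compound 1 to compound 3. Whether compound 1, compound 2 and compound 3 differ at all in this assay stays open, because all three sit at the same limit: the limit of > 95% in this assay, at which 3 of the 3 values shown sit.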